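Quinazoline acrylamides on prostate cancer cells: a pyrrolidine variant

The compounds below may be only part of what the source reports. "The series", "measured", "known", "first", "only" and "open" are said of these compounds alone.

Measured compounds and their results in a functional assay on PC-3 cells (Homo sapiens) for antiproliferative activity, read by MTT assay, with a stated time of 72 h; a lower number here means a stronger inhibitor, a higher number a weaker inhibitor:
compound 1 `C=CC(=O)Nc1cc2c(N3CCc4ccccc43)ncnc2cc1OC` gives 5940 nM;
compound 2 `C=C(C)C(=O)Nc1cc2c(N3CCc4ccccc43)ncnc2cc1OC` gives 4830 nM;
compound 3 `CCC/C=C/C(=O)Nc1cc2c(N3CCc4ccccc43)ncnc2cc1OC` gives 4240 nM.

Compound 3 has the lowest number of the three, but its separation from the others is slight: the steps of a 1.4-fold lower number from compound 1 to compound 3 (0.15 log units; within the scatter) and a 1.1-fold lower number from compound 2 to compound 3 (0.06 log units; within the scatter) both sit inside the scatter, as does a 1.2-fold lower number from compound 1 to compound 2 (0.09 log units; within the scatter). On these numbers the three compounds cannot be told apart.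

Compound 4 `COc1cc2ncnc(N3CCc4ccccc43)c2cc1NC(=O)/C=C/CN1CCCC1` takes the step (pyrrolidin-1-yl in place of ethyl on a saturated chain carbon bound to a double-bonded chain carbon). Going by the values given here, no measured pair tests anything like this: the three steps seen all alter the chain on the carbonyl carbon by hydrogen-to-methyl or by lengthening, and each stays within the scatter. The data give no basis for expecting a move in either direction, so compound 4 is expected to land near compound 3, with a wide band around it. Compound 4 is thus estimated at 3500 nM, with a range from 800 nM to 15000 nM, which would mean a step of a 1.2-fold lower number from compound 3 to compound 4 (0.08 log units; within the scatter) and is expected to stay within the scatter.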

Compound 4, half-maximal inhibitory concentration: 2620 nM
For compound 4 the middle estimate is 1.3-fold (0.13 log units) above the measured one, and the stated range covers the measured number.
By their numbers in this assay, from the lowest: compounds 4, 3, 2 and 1 (each within the scatter of the next, the first and the last beyond it).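

In this assay the pyrrolidin-1-yl in place of ethyl on a saturated chain carbon gives a 1.6-fold lower number from compound 3 to compound 4 (0.21 log units; within the scatter) and so does not separate these two compounds, and the wider change gives a 1.8-fold lower number from compound 2 to compound 4 (0.27 log units; within the scatter) and also stays inside the scatter. The one step that does clear the scatter, modestly, is a 2.3-fold lower number from compound 1 to compound 4 (0.36 log units; beyond the scatter) and it is the only separation among the compounds shown, which none of the earlier steps achieved. Nothing given here accounts for that step.

The compounds shown leave open whether a dimethylamino group, a piperidine ring or a cyclopentyl ring at this place would give a number apart from that of compound 4. They therefore also leave open whether the ring or its nitrogen goes with the step away from compound 1.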